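The compounds below may be only part of what the source reports. "The series", "measured", "known", "first", "only" and "open" are said of these compounds alone.

The measured compounds:
compound 1 `CCCCc1nc(=O)c(S(=O)(=O)c2ccc(-c3ccnc(NC(=O)C4CC4)c3)cc2)c(O)n1-c1c(OC)cccc1OC`, giving 72% in an ADME assay on microsomes from liver (Mus musculus) for metabolic stability, using NADPH, with a stated time of 10 min; a lower number here means that less of the compound is left, a higher number that more of the compound is left;
compound 2 `CCCCc1nc(=O)c(S(=O)(=O)c2ccc(-n3ccccc3=O)cc2)c(O)n1-c1c(OC)cccc1OC`, giving 63% in this assay;
compound 3 `CCCCc1[nH]c(=O)c(S(=O)(=O)c2ccc(-c3ccc(F)cc3)cc2)c(O)c1-c1c(OC)cccc1OC`, giving "not determined" (no result reported) in this assay, that is, no result is reported for it.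

Compound 3 therefore stands nowhere on the numbers: its percent of compound remaining was not determined, so no starting point for the next step can be stated. Compound 4 `CCCCc1[nH]c(=O)c(S(=O)(=O)c2ccc(-c3ccncc3C)cc2)c(O)c1-c1c(OC)cccc1OC` differs from it by 3-methylpyridin-4-yl in place of 4-fluorophenyl on an aromatic carbon. Among the measured compounds shown here, only one step between measured compounds exists, a number 9 percentage points lower from compound 1 to compound 2 (within the scatter), and that step concerns a different exchange on a different core; it does not bear on the change from compound 3 to compound 4. Compounds 1 and 2, which share much of their structure with compound 3 and compound 4, both keep a fair share of material remaining in this assay. For the measured compounds named here, no measured step tells the direction or the size of the change from compound 3 to compound 4, so any figure is a loose guess anchored on compounds 1 and 2. Compound 4 is expected, with wide uncertainty, to give about 60% in this assay, estimated to lie between 35% and 85%.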

Compound 4, percent of the compound remaining: 39%
Compound 4: middle estimate off by 21 percentage points, on the high side; measured number inside the range.
By their numbers in this assay, from the lowest: compound 4; then compounds 2 and 1 (each within the scatter of the next).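

Among the compounds shown here, with no number for compound 3 in this assay, the change from compound 3 to compound 4 gives no step that can be read. The compounds shown leave open what 3-methylpyridin-4-yl does in place of 4-fluorophenyl in this assay. Nothing at hand bears on the result.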